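Adding a methyl to the double-bonded chain carbon

The source may report more compounds than this note shows. Statements on the series, on what has been measured and on what is new or still open speak of the compounds shown alone.

compound 1 `CC(C)=C1C(=O)N(c2ccc(Cl)cc2)N(c2ccc(Cl)cc2)C1=O` gives 39600 nM
compound 2 `CCC(C)=C1C(=O)N(c2ccc(Cl)cc2)N(c2ccc(Cl)cc2)C1=O` gives 41600 nM
compound 3 `O=C1C(=Cc2ccc(O)cc2)C(=O)N(c2ccc(Cl)cc2)N1c1ccc(Cl)cc1` gives 23200 nM

In a functional assay on MCF7 cells (Homo sapiens) for cytotoxicity, read by MTT assay, with a stated time of 72 h (on this read-out higher numbers stand for weaker inhibition and lower numbers for stronger inhibition), compound 3 gives 23200 nM and cannot be told apart from compound 1 (39600 nM) or compound 2 (41600 nM), since all three lie within the usual scatter of repeated measurements.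

Compound 4 `CC(=C1C(=O)N(c2ccc(Cl)cc2)N(c2ccc(Cl)cc2)C1=O)c1ccc(O)cc1` differs from compound 3 by methyl in place of hydrogen on a double-bonded chain carbon bound to an aromatic carbon and a double-bonded ring carbon. Among the compounds with values here, the one measured step with a similar swap is a 1.1-fold higher number from compound 1 to compound 2 (0.02 log units; within the scatter) for methyl in place of hydrogen on a saturated chain carbon bound to a double-bonded chain carbon. Within the data shown here, that is a different carbon, so this step is only a loose guide, and no measurement yet shows a methyl on the carbon that changes here. Compound 1 (39600 nM) and compound 2 (41600 nM) also carry no hydrogen on their double-bonded chain carbon, and their values stay within the scatter of compound 3 (23200 nM) all the same.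

The expected step of a 1.2-fold higher number from compound 3 to compound 4 (0.08 log units; within the scatter) in this assay is therefore expected to stay within the scatter. Compound 4 is estimated at 28000 nM with an expected range from 13000 nM to 55000 nM for this measurement.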

Compound 4, half-maximal inhibitory concentration: 76500 nM
Beside the measured number, compound 4's estimate is 2.7-fold (0.44 log units) below it, and the stated range ends below it.
By their numbers in this assay, from the lowest: compounds 3, 1, 2 and 4 (each within the scatter of the next, the first and the last beyond it).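

In this assay, within the data shown here, the methyl on a double-bonded chain carbon bound to an aromatic carbon and a double-bonded ring carbon gives a 3.3-fold higher number from compound 3 to compound 4 (0.52 log units; beyond the scatter) and so weakens inhibition modestly, the only step here beyond the scatter, while the methyl on a saturated chain carbon gave a 1.1-fold higher number from compound 1 to compound 2 (0.02 log units; within the scatter) and stayed within it. With that methyl in place, 4-hydroxyphenyl in place of ethyl gives a 1.8-fold higher number from compound 2 to compound 4 (0.26 log units; within the scatter) and 4-hydroxyphenyl in place of methyl gives a 1.9-fold higher number from compound 1 to compound 4 (0.29 log units; within the scatter) and both steps stay within the scatter, so compound 4 cannot be told apart from compound 1 or compound 2 even though compound 3 and compound 4 can be told apart. Nothing available gives a reason for the effect of this methyl at this carbon.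

Among the compounds shown, this carbon carries only hydrogen or methyl alongside the 4-hydroxyphenyl group, so how an ethyl or a longer chain would read there remains open. From the compounds shown here alone, it also remains open whether the methyl would give a similar step if an amine or a carboxylic acid stood in place of the hydroxyl on the aromatic ring.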